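The source may hold more compounds than are shown below. What is called first, only, known or untested is meant among the compounds shown, and "the series" means these compounds.

In a functional assay on KB cells (Homo sapiens) for antiproliferative activity, read by MTT assay, with a stated time of 72 h (a higher number here means a weaker inhibitor, a lower number a stronger inhibitor), compound 1 `CCOC(=O)c1cc(-c2ccc(OC)cc2)c(-c2cc(OC)c(OC)c(OC)c2)s1`, which carries an ethyl ester, gives 10200 nM, and compound 2 `COc1ccc(-c2cc(C(=O)O)sc2-c2cc(OC)c(OC)c(OC)c2)cc1`, which carries carboxy at that spot, gives 8650 nM. Compound 3 `COc1ccc(-c2cc(C(=O)O)sc2-c2cc(OC)c(OC)c(OC)c2)cc1OCc1ccccc1` reads > 100000 nM, and this is a limit of the assay, not a number. Within the data shown here, compound 2 therefore stands level with compound 1 within the scatter, and these two hold the only actual numbers in the set.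

Compound 4 `COc1ccc(-c2ccsc2-c2cc(OC)c(OC)c(OC)c2)cc1` differs from compound 2 by one change, hydrogen in place of carboxy on an aromatic carbon. Two measured steps can be weighed against it. The closest guide alters the same group and gives a 1.2-fold lower number from compound 1 to compound 2 (0.07 log units; within the scatter), so that edit left the number within the scatter. However, the carbonyl stays in place there, so losing the whole group remains untested. The other step gives an at least 11-fold higher number from compound 2 to compound 3 (1.06 log units; beyond the scatter), which is large, but it adds benzyloxy elsewhere and so says little about this change. Among the measured compounds shown here, with only that weak guide, a modest shift toward a lower number is expected, while either direction stays possible. The expected change is a 2.2-fold lower number from compound 2 to compound 4 (0.33 log units; beyond the scatter). Compound 4 is estimated at 4000 nM, with an expected range from 400 nM to 25000 nM.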

Compound 4, half-maximal inhibitory concentration: 7400 nM
Compound 4: the middle estimate sits 1.9-fold (0.27 log units) below what was measured; the measured number falls inside the stated range.
By their numbers in this assay, from the lowest: compounds 4, 2 and 1 (each within the scatter of the next). At a limit, above all of these: compound 3.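

In this assay, hydrogen in place of carboxy gives a 1.2-fold lower number from compound 2 to compound 4 (0.07 log units; within the scatter), and hydrogen in place of ethoxycarbonyl gives a 1.4-fold lower number from compound 1 to compound 4 (0.14 log units; within the scatter). The earlier step between the ester and the acid kept the carbonyl in place, whereas these steps remove the whole group from the aromatic carbon next to the ring sulfur, and the number still stays within the scatter, so ethoxycarbonyl, carboxy and bare hydrogen cannot be told apart at this place in this assay. Nothing measured here offers a cause for this flat result.

From the compounds shown here alone, whether any group at this carbon can move the number at all remains open, and an amine, an amide or a longer alkyl chain there would be a first test of that. Also open, going by these compounds, is whether the benzyloxy group would act the same way on the core without carboxy, given that compound 3 reads > 100000 nM, which is a limit of the assay.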